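A few compounds are considered here, and "the series" means these few. Any claim that something is new, unique, unknown or untested is made for them only; others in the source may bear on it.

Series notes. Compound 1 `Cc1ccc(OCC(=O)N(Cc2cccs2)c2c[nH]nc2C)cc1` gives 0.4 nM in an assay on HEK293 cells for agonist activity at transient receptor potential cation channel subfamily M member 8 (Homo sapiens), read by fluorescence and calcium flux, with a stated time of 15 min; a higher number here means that more compound is needed for the effect, a lower number that less compound is needed. Among the compounds with values here, compound 2 `Cc1ccc(OCC(=O)N(Cc2cccs2)c2cccnc2)cc1` gives 198 nM, and the single measured step, a 500-fold higher number from compound 1 to compound 2 (2.69 log units; beyond the scatter), places compound 2 as the higher of the two numbers so far, with compound 1 the only neighbour.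

The next compound, compound 3 `Cc1ccc(OCC(=O)N(Cc2cccs2)c2cnccn2)cc1`, keeps the core of compound 2 and changes the group on the amide-type nitrogen: pyrazin-2-yl in place of pyridin-3-yl on an amide-type nitrogen. Within the data shown here, only the step from compound 1 to compound 2 bears on this position, and it was large; it shows that the group on this nitrogen matters strongly, but it compares a five-membered ring with a six-membered one and gives no direct read on swapping one six-membered aromatic ring for another. The expectation is therefore a step of modest size, a 2.0-fold higher number from compound 2 to compound 3 (0.31 log units; beyond the scatter), with the direction uncertain and a somewhat higher number slightly favoured. Compound 3 is estimated at 400 nM, within a range of 100 nM to 2000 nM.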

Compound 3, half-maximal effective concentration: 1240 nM
Estimate against measurement, compound 3: 3.1-fold (0.49 log units) below; low and high end bracket the measured number.
By their numbers in this assay, from the lowest: compound 1; then compound 2; then compound 3.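

In this assay, the exchange of one six-membered aromatic ring for another on the amide-type nitrogen is enough to move the number, with a 6.3-fold higher number from compound 2 to compound 3 (0.80 log units; beyond the scatter) at an unchanged heavy-atom count, so this position responds to more than ring size. The gap to the five-membered group grows further, with a 3100-fold higher number from compound 1 to compound 3 (3.49 log units; beyond the scatter) as the widest step among the three compounds, and 3-methyl-1H-pyrazol-4-yl holds the lowest number of the three. No measurement on these compounds accounts for either step.

Still open, from the compounds shown here alone, is how much of the low number of compound 1 belongs to the methyl group and how much to the ring hydrogen on nitrogen, which a plain 1H-pyrazol-4-yl would help separate. A pyridin-4-yl or a pyrimidin-5-yl on the same nitrogen would show whether the ring nitrogens' number or their placing drives the rise.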